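The source may hold more compounds than are shown below. What is called first, only, known or untested is meant among the compounds shown, and "the series" means these compounds.

compound 1 `COc1cccc(C#Cc2cc(Cl)cn3c([N+](=O)[O-])c(CS(=O)(=O)c4ccccc4)nc23)c1`: > 3900 nM
compound 2 `O=[N+]([O-])c1c(CS(=O)(=O)c2ccccc2)nc2c(C#Cc3ccccc3F)cc(Cl)cn12`: > 3900 nM
compound 3 `Nc1ccc(C#Cc2cc(Cl)cn3c([N+](=O)[O-])c(CS(=O)(=O)c4ccccc4)nc23)cc1`: > 3900 nM

These results come from an ADME assay on HepG2 cells (Homo sapiens) for cytotoxicity, read by MTT assay, with a stated time of 72 h (on this read-out lower numbers stand for higher toxicity in this test and higher numbers for lower toxicity in this test), and each is a limit of the test rather than a number. Compound 3 gives > 3900 nM, which is a limit, so its exact place among the others cannot be read. What the series shows is the limit of > 3900 nM in this assay, at which 3 of the 3 values shown sit.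

Compound 4 `O=[N+]([O-])c1c(CS(=O)(=O)c2ccccc2)nc2c(C#Cc3cccs3)cc(Cl)cn12` differs from compound 3 in one group: thiophen-2-yl in place of 4-aminophenyl on a triple-bonded carbon. Thiophen-2-yl stands in place of 4-aminophenyl on a triple-bonded carbon.

The measured steps that bear on this change swap groups at the same place: a step that the two limits leave unreadable from compound 1 to compound 3, a step that the two limits leave unreadable from compound 2 to compound 3 and a step that the two limits leave unreadable from compound 1 to compound 2. None of them has a readable size, so they offer no direction. No change beyond the usual scatter is therefore expected, and a further limit is the likeliest result. The expected size is a step that the limit leaves unreadable from compound 3 to compound 4. For compound 4 the estimated value is 5000 nM, with an expected range from 2500 nM to 10000 nM.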

Compound 4, half-maximal cytotoxic concentration: > 3900 nM
Compound 4: only a limit was reported; the forecaster's own chance of this, stated with the estimate: 85%; the middle value is on the limit's open side.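

In this assay compound 4 gives > 3900 nM, which is a limit, so its steps from compound 1, compound 2 and compound 3 cannot be read. On these data alone, whether changing the group on the triple-bonded carbon alters the result in this test stays open.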